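The source may report more compounds than this note shows. Statements on the series, on what has been measured and on what is new or still open speak of the compounds shown alone.

Measured so far in a functional assay on HeLa cells (Homo sapiens) for antiproliferative activity, read by CCK-8 assay, with a stated time of 72 h, tested at 2 uM; on this read-out higher numbers stand for a stronger effect at the one concentration tested and lower numbers for a weaker effect:
compound 1, `Nc1ccccc1NC(=O)c1ccc(CSC(=S)N2CCN(Cc3ccccn3)CC2)cc1`, gives 14.2%
compound 2, `Nc1ccccc1NC(=O)c1ccc(CSC(=S)N2CCN(c3cccnc3)CC2)cc1`, gives 66.2%
compound 3, `Nc1ccccc1NC(=O)c1ccc(CSC(=S)N2CCN(c3ccc(F)cc3)CC2)cc1`, gives 60.8%

Compound 3 holds the second highest of these three numbers. Its nearest neighbour is compound 2, and the step of a number 5.4 percentage points lower from compound 2 to compound 3 (within the scatter) lies within the scatter, so the two cannot be ranked against each other. Compound 1 is the furthest away, as the step of a number 46.6 percentage points higher from compound 1 to compound 3 (beyond the scatter) shows.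

Compound 4, `N#Cc1ccc(N2CCN(C(=S)SCc3ccc(C(=O)Nc4ccccc4N)cc3)CC2)cc1`, differs from compound 3 in one place: cyano in place of fluoro on an aromatic carbon. Among the measured steps, only a number 5.4 percentage points lower from compound 2 to compound 3 (within the scatter) concerns an exchange of one aromatic group for another on the ring nitrogen, and that step stayed within the scatter. The two large steps, a number 52 percentage points higher from compound 1 to compound 2 (beyond the scatter) and a number 46.6 percentage points higher from compound 1 to compound 3 (beyond the scatter), both replace (pyridin-2-yl)methyl by an aromatic group bound directly to the ring nitrogen, and say nothing about a substituent swap on such an aromatic group. Among the compounds with values here, no measured pair addresses cyano in place of fluoro at all. The expectation is therefore a step of a number 1.2 percentage points higher from compound 3 to compound 4 (within the scatter), that is, none beyond the scatter. For compound 4 the estimated value is 62%, with an expected range from 45% to 78%.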

Compound 4, a percentage reported as inhibition, at one concentration (the size of the read-out at that concentration, not a potency): 71.6%
Compound 4: the middle estimate sits 9.6 percentage points below what was measured; measured number inside the range.
By their numbers in this assay, from the lowest: compound 1; then compounds 3, 2 and 4 (each within the scatter of the next, the first and the last beyond it).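

In this assay, within the data shown here, the step of a number 10.8 percentage points higher from compound 3 to compound 4 (beyond the scatter) is the first change within a directly bound aromatic group to go beyond the scatter, though it is only modest. Among these compounds, it shows that exchanging one small group for another on an aromatic carbon para to a large group can move the read-out, and the earlier compounds did not test this kind of exchange. The step of a number 5.4 percentage points higher from compound 2 to compound 4 (within the scatter) leaves 4-cyanophenyl and pyridin-3-yl unranked against each other, while the step of a number 57.4 percentage points higher from compound 1 to compound 4 (beyond the scatter) adds a third directly bound aromatic group that stands well apart from (pyridin-2-yl)methyl on the ring nitrogen. Nothing available on these compounds offers an explanation for the gain from the cyano group.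

The compounds shown leave open how a methoxy group, an amine or a carboxylic acid would read at this same place, and whether a plain phenyl group would fall with the fluoro or the cyano compound. They also leave open whether the gap in effect between compound 3 and compound 4 would persist at other concentrations, since this assay reports a single concentration.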